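The source may report more compounds than this note shows. Statements on the series, on what has been measured and on what is new or still open speak of the compounds shown alone.

In a functional assay on the whole organism for inhibition, with Rattus norvegicus as the target, read by paw edema, at a dose of 100 mg/kg by the oral route (a lower number here means less inhibition, a higher number more inhibition at the dose given (going by the name of the read-out)), three compounds built on one shared core have been measured. Compound 1 `CCOC(=O)c1c(O)c2cccnc2n(-c2ccccc2)c1=O` gives 23.5%. Compound 2 `Nc1ccc(NC(=O)c2c(O)c3cccnc3n(-c3ccccc3)c2=O)cc1` gives -5.5%, and compound 3 `O=C(Nc1cccc(Cl)c1)c1c(O)c2cccnc2n(-c2ccccc2)c1=O` gives 7.6%. Among these three numbers compound 3 stands second highest: the step of a number 13.1 percentage points higher from compound 2 to compound 3 (beyond the scatter) separates it from its nearest neighbour, and the step of a number 15.9 percentage points lower from compound 1 to compound 3 (beyond the scatter) separates it from the furthest.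

Compound 4 `Cc1ccccc1NC(=O)c1c(O)c2cccnc2n(-c2ccccc2)c1=O` has not yet been measured. It differs from compound 3 at a single place: 2-methylphenyl in place of 3-chlorophenyl on an amide-type nitrogen. For the measured compounds named here, both compounds keep an aryl group on the amide-type nitrogen, so the only measured step of the same kind is a number 13.1 percentage points higher from compound 2 to compound 3 (beyond the scatter), a modest movement for a swap of one aryl group for another at that nitrogen. The steps of a number 29 percentage points lower from compound 1 to compound 2 (beyond the scatter) and a number 15.9 percentage points lower from compound 1 to compound 3 (beyond the scatter) replaced the ethoxy group rather than one aryl group by another, and both lowered inhibition, which says little about the present swap. Going by the values given here, with only one aryl-to-aryl step known, and that one modest, the expected step of a number 2.4 percentage points higher from compound 3 to compound 4 (within the scatter) is small, in either direction, and may fall within the scatter. Compound 4 is therefore estimated at 10%, with a range from -8% to 28%.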

Compound 4, a percentage reported as inhibition, in the whole organism at one dose (the size of the read-out at that dose, not a potency): 11.7%
Beside the measured number, compound 4's estimate is 1.7 percentage points below it, and the stated range covers the measured number.
By their numbers in this assay, from the lowest: compound 2; then compounds 3 and 4 (each within the scatter of the next); then compound 1.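

In this assay the change from 3-chlorophenyl to 2-methylphenyl on the amide-type nitrogen gives a number 4.1 percentage points higher from compound 3 to compound 4 (within the scatter) and so does not separate these two amides, the first aryl-to-aryl step shown here that stays within the scatter. The 4-aminophenyl amide now stands apart from two other aryl amides, with a number 17.2 percentage points higher from compound 2 to compound 4 (beyond the scatter) in the same direction as the step already seen for 3-chlorophenyl. Replacing ethoxy with (2-methylphenyl)amino gives a number 11.8 percentage points lower from compound 1 to compound 4 (beyond the scatter) and thus leaves this third amide under the ester as well, while no evidence at hand explains any of these steps.

The single swap alters both the group and its place on the phenyl ring, so the compounds shown leave open whether 2-chlorophenyl or 3-methylphenyl would read like compound 3 and compound 4. They also leave open how an amide bearing a butyl chain or a benzyl group instead of an aryl group would read, and whether a carboxylic acid in place of the ester would keep its level of inhibition.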